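A few compounds are considered here, and "the series" means these few. Any claim that something is new, unique, unknown or untested is made for them only; others in the source may bear on it.

Measured so far:
compound 1 `O=C(Nc1cccc(-n2cc(-c3ccncc3)c(-c3ccc(Cl)c(O)c3)n2)c1)Nc1cccc(C(F)(F)F)c1` — 1340 nM
compound 2 `COc1cc(-c2nn(-c3cccc(NC(=O)Nc4cc(C(F)(F)F)cc(C(F)(F)F)c4)c3)cc2-c2ccncc2)ccc1Cl` — 307 nM

Two compounds have been run in a functional assay on RPMI-8226 cells (Homo sapiens) for inhibition, read by sulforhodamine B assay, with a stated time of 48 h; a higher number here means a weaker inhibitor of growth, a lower number a stronger inhibitor of growth. There compound 1 gives 1340 nM, while compound 2 gives 307 nM. Compound 1 therefore carries the highest number of the two, and compound 2 sits below it by a gap that goes beyond the usual scatter. The two differ in more than one place, so no single-point comparison between them is available, and their two values can only be taken as they stand.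

Compound 3 `O=C(Nc1cccc(-n2cc(-c3ccncc3)c(-c3ccc(Cl)c(O)c3)n2)c1)Nc1ccc(Cl)c(Cl)c1` has not yet been measured. It is built from compound 1 by one change: 3,4-dichlorophenyl in place of 3-(trifluoromethyl)phenyl on an amide-type nitrogen. Among the measured compounds shown here, no measured pair tells how this change plays out here. Both groups are halogen-bearing aryl rings on the same urea nitrogen, so the step from compound 1 to compound 3 in this assay is expected to be modest, most likely within the scatter, with a slight lean toward a lower number. The estimated result for compound 3 is 900 nM, with a range from 300 nM to 3000 nM, which implies an expected step of a 1.5-fold lower number from compound 1 to compound 3 (0.17 log units; within the scatter).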

Compound 3, concentration for 50% growth inhibition: 1030 nM
Compound 3: middle estimate off by 1.1-fold (0.06 log units), on the low side; the range from low to high includes it.
By their numbers in this assay, from the lowest: compound 2; then compounds 3 and 1 (each within the scatter of the next).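

In this assay, 3,4-dichlorophenyl in place of 3-(trifluoromethyl)phenyl on the amide-type nitrogen gives a 1.3-fold lower number from compound 1 to compound 3 (0.11 log units; within the scatter), so the two compounds cannot be told apart. Among the compounds shown here, this is the first comparison here in which only one place differs, and it shows that, on the core of compound 1, these two halogen-bearing aryl groups give results within the usual scatter of each other. No measurement of any property of the two groups is available to account for this result.

This single pair says nothing about whether the same holds on other cores or for groups without halogen at this nitrogen, such as a plain phenyl, a methoxyphenyl or a cyclohexyl group. Compound 2 differs from compound 1 and from compound 3 in more than one place, so the compounds shown cannot tell which of its differences matters in this assay, and what a single change at any other position would do remains open.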